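Chain Length and Acyl Swap in a Cytotoxicity Series

This account rests on a few compounds, and the source may have more. Where it says the series, first, only, none or still open, it means among the compounds named here.

Measured compounds:
compound 1, `CCCCCCCCNC(=O)[C@@H](NC(=O)/C=C/c1ccccc1)[C@@H](C)O`, 35100 nM
compound 2, `C/C=C/C=C/C(=O)N[C@H](C(=O)NCCCCCCCC)[C@@H](C)O`, 149000 nM
compound 3, `CCCCCCCCCCCCCCCCCCNC(=O)[C@@H](NC(=O)/C=C/c1ccccc1)[C@@H](C)O`, 39200 nM

These three amides share a threonine-derived core and were tested in a functional assay on MCF7 cells (Homo sapiens) for cytotoxicity, read by MTT assay, with a stated time of 48 h; a higher number here means a weaker inhibitor, a lower number a stronger inhibitor. Compound 1 and compound 2 differ by prop-1-en-1-yl in place of phenyl on a double-bonded chain carbon bound to a double-bonded chain carbon; that change gave a 4.2-fold higher number from compound 1 to compound 2 (0.63 log units; beyond the scatter). Compound 3 carries decyl in place of hydrogen on a saturated chain carbon, eight bonds along the chain from an amide-type nitrogen relative to compound 1, and the step of a 1.1-fold higher number from compound 1 to compound 3 (0.05 log units; within the scatter) shows that the longer chain left the number essentially unchanged.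

Compound 4, `C/C=C/C=C/C(=O)N[C@H](C(=O)NCCCCCCCCCCCCCCCCCC)[C@@H](C)O`, is not yet measured. It stands to compound 3 as compound 2 stands to compound 1: the difference is prop-1-en-1-yl in place of phenyl on a double-bonded chain carbon bound to a double-bonded chain carbon, the same change made at the same place. The two cores differ only by decyl in place of hydrogen on a saturated chain carbon, eight bonds along the chain from an amide-type nitrogen, a change that in this assay barely moved the number.

The step from compound 3 to compound 4 is therefore expected to resemble the earlier one, because a 4.2-fold higher number from compound 1 to compound 2 (0.63 log units; beyond the scatter) was measured on a core that behaves like that of compound 3; the estimated step is a 4.2-fold higher number from compound 3 to compound 4 (0.62 log units; beyond the scatter). For compound 4 the expected value in this assay is 165000 nM, with a likely range of 60000 nM to 400000 nM.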

Compound 4, half-maximal inhibitory concentration: 79600 nM
Compound 4: the middle estimate sits 2.1-fold (0.32 log units) above what was measured; low and high end bracket the measured number.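

In this assay the change to prop-1-en-1-yl in place of phenyl again gave a step beyond the scatter (a 2.0-fold higher number from compound 3 to compound 4 (0.31 log units; beyond the scatter)), in the same direction as on the shorter-chain core, and the two steps do not differ beyond what two such steps can scatter: the same change on two cores in this assay, a 4.2-fold higher number (0.63 log units; beyond the scatter) from compound 1 to compound 2 and a 2.0-fold higher number (0.31 log units; beyond the scatter) from compound 3 to compound 4, 2.1-fold (0.32 log units) apart, within the scatter of two such steps.

The decyl change likewise stayed within the scatter on the second core (a 1.9-fold lower number from compound 2 to compound 4 (0.27 log units; within the scatter)), so it agrees with its earlier counterpart: the same change on two cores in this assay, a 1.1-fold higher number (0.05 log units; within the scatter) from compound 1 to compound 3 and a 1.9-fold lower number (0.27 log units; within the scatter) from compound 2 to compound 4, 2.1-fold (0.32 log units) apart, within the scatter of two such steps.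

This shows that, in these two matched pairs, the change carried over from one core to the other in direction, but two pairs fix no exact size for the step, and they show nothing about cores that differ in any other place.

The compounds shown leave open how the change behaves with a chain of intermediate length, such as dodecyl, or a shorter one, such as butyl. Also open, from the compounds shown here alone, is what a saturated acyl chain, a fluorine on the phenyl ring, or an amine in place of the hydroxyl would give.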